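Swapping methyl for chloro on compound 1

The source may report more compounds than this note shows. Statements on the series, on what has been measured and on what is new or still open speak of the compounds shown alone.

Measured in a functional assay on CNS cells (Homo sapiens) for antiproliferative activity; a lower number here means a stronger inhibitor of growth, a higher number a weaker inhibitor of growth:
Compound 1 `Cc1cn2c(/C=N/NC(=N)N)c(-c3ccncc3)nc2s1`: 30900 nM
Compound 2 `Cc1cn2c(/C=N/NC(=N)N)c(-c3cccnc3)nc2s1`: 28200 nM
Compound 3 `N=C(N)N/N=C/c1c(-c2cc([N+](=O)[O-])c(Cl)cc2Cl)nc2sc(Cl)cn12`: 64600 nM

Compound 1 stands level with compound 2, as the two lie within the scatter of each other. Compound 3 has a higher number than compound 1, and that gap lies beyond the scatter.

Compound 4 `N=C(N)N/N=C/c1c(-c2ccncc2)nc2sc(Cl)cn12` has not yet been measured. It keeps the core of compound 1 and its pyridin-4-yl group, and differs in a single place: chloro in place of methyl on an aromatic carbon. Going by the values given here, no measured step makes this exact change. Among the compounds with values here, the one step available, a 1.1-fold lower number from compound 1 to compound 2 (0.04 log units; within the scatter), concerns a different part of the molecule, with pyridin-3-yl in place of pyridin-4-yl, so it bears only indirectly.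

The closest hint is compound 3, which also carries chloro next to the ring sulfur and gives 64600 nM. However, compound 3 also differs from compound 1 in its other aromatic ring, so the chloro cannot be credited with any share of that value. A step beyond the scatter is therefore not expected, with at most a slight lean towards a higher number in this assay. The estimated step is a 1.1-fold higher number from compound 1 to compound 4 (0.05 log units; within the scatter). For compound 4 the expected value is 35000 nM, with an estimated range of 16000 nM to 72000 nM.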

Compound 4, concentration for total growth inhibition: 20000 nM
Compound 4: middle estimate off by 1.8-fold (0.24 log units), on the high side; the measured number falls inside the stated range.
By their numbers in this assay, from the lowest: compounds 4, 2 and 1 (each within the scatter of the next); then compound 3.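

In this assay, putting chloro in place of methyl on the aromatic carbon next to the ring sulfur gives a 1.5-fold lower number from compound 1 to compound 4 (0.19 log units; within the scatter), so this assay does not separate the two groups at this position. Going by these compounds alone, until now, chloro at this carbon appeared only in compound 3, which also carries a different second aromatic ring, whereas compound 4 keeps the pyridin-4-yl group and so gives the first direct reading of this single swap. Nothing among the data shown offers an explanation for how either group acts at this position.

Within the data shown here, what an amine, a carboxylic acid or a longer chain such as propyl would do on this same carbon stays open, since methyl and chloro are the only two groups compared here in a single-change pair. From the compounds shown here alone, it is also open whether the swap from methyl to chloro would read the same way with the pyridin-3-yl group of compound 2 in place of the pyridin-4-yl group.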